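The source may report more compounds than this note shows. Statements on the series, on what has been measured and on what is new or still open speak of the compounds shown alone.

Of the compounds shown here, two have so far been measured in an ADME assay on microsomes from liver (Mus musculus) for metabolic stability, read by LC-MS, with a stated time of 10 min; a higher number here means that more of the compound is left, a lower number that less of the compound is left. Compound 1 (`CN(C[C@@H]1Cc2c(cccc2N2CCNCC2)CN1)[C@H]1CCCc2cccnc21`) gives 54.6%, and compound 2 (`C[C@@H]1CN(c2cccc3c2C[C@H](CN(C)[C@H]2CCCc4cccnc42)NC3)C[C@H](C)N1C`) gives 39.6%. Compound 2 is therefore the lower of the two, and its gap to compound 1 lies beyond the usual scatter. The next compound, compound 3 (`CN(C[C@H]1Cc2c(cccc2N2CCNCC2)CN1)[C@H]1CCCc2cccnc21`), differs from compound 2 by one change on an aromatic carbon, piperazin-1-yl in place of 3,4,5-trimethylpiperazin-1-yl (piperazin-1-yl in place of 3,4,5-trimethylpiperazin-1-yl on an aromatic carbon). Among the compounds with values here, no two measured compounds show this change on its own, so any expectation is rough. Compound 1 carries piperazin-1-yl and gives 54.6%, which points upward. The change is expected to be upward and modestly beyond the scatter, with an estimated a number 12.4 percentage points higher from compound 2 to compound 3 (beyond the scatter). For compound 3 the expected value is 52%, with an estimated range of 36% to 69%.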

Compound 3, percent of the compound remaining: 19.9%
Compound 3: the middle estimate sits 32.1 percentage points above what was measured; the measured number lies below the stated range.
By their numbers in this assay, from the lowest: compound 3; then compound 2; then compound 1.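

In this assay, piperazin-1-yl in place of 3,4,5-trimethylpiperazin-1-yl on the aromatic carbon gives a number 19.7 percentage points lower from compound 2 to compound 3 (beyond the scatter), so this change does not raise the number by itself. With piperazin-1-yl kept, inverting the stereocentre at a saturated ring carbon gives a number 34.7 percentage points lower from compound 1 to compound 3 (beyond the scatter), which shows that the piperazin-1-yl group alone does not set the amount of compound left. The shift comes from the three-dimensional arrangement and not from a change in the groups present, because of what this pair holds fixed: the fact that compounds 1 and 3 differ only in the configuration as drawn

The compounds shown leave open how 4-methylpiperazin-1-yl or morpholin-4-yl would read at this aromatic carbon under either configuration. They also do not show why one configuration leaves less compound than the other, or what the second stereocentre contributes.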